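The compounds below may be only part of what the source reports. "The series", "measured", "known", "first", "only" and "open" are said of these compounds alone.

Working notes on the peroxide series. Compound 1 `C=C1CCCC(C)(C)C1CC[C@]1(C)CC[C@@H]([C@@H](C)C(=O)O)OO1` is measured in a functional assay on UACC-62 cells (Homo sapiens) for inhibition (on this read-out lower numbers stand for stronger inhibition of growth and higher numbers for weaker inhibition of growth), only as a limit: in this assay compound 1 gives > 10000 nM, which is a limit of the assay and not a number. Where compound 1 stands is therefore set by the limit of > 10000 nM in this assay, at which 1 of the 2 values shown sits. Among the measured compounds shown here, compound 2 `C=C1CCCC(C)(C)C1CC[C@]1(C)CC[C@H]([C@@H](C)C(=O)OC)OO1` is the one member with a number: in this assay compound 2 gives 4130 nM. For the measured compounds named here, no pair of measured compounds differing in one place is available, so no measured step exists to lean on. Compound 3 `C=C1CCCC(C)(C)C1CC[C@@]1(C)CC[C@H]([C@@H](C)C(=O)O)OO1` differs from compound 1 by the two compounds have the same atoms and bonds; at least one stereo element is drawn with a configuration in one of them and without one in the other: 2 of 4 stereo elements differ; a stereocentre at a saturated ring carbon is drawn R in compound 1 and S in compound 3; a stereocentre at a saturated ring carbon is drawn S in compound 1 and R in compound 3. With compound 1 at > 10000 nM, no direction can be read for this change, and the expectation is a step that the limit leaves unreadable from compound 1 to compound 3, not beyond the scatter. Compound 3 is accordingly estimated at 12000 nM, with a range from 3000 nM to 40000 nM, and a report of a limit only is expected as the most likely outcome.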

Compound 3, concentration for 50% growth inhibition: 9240 nM
Estimate against measurement, compound 3: 1.3-fold (0.11 log units) above; low and high end bracket the measured number.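

Changing the configuration at two saturated ring carbons, with atoms and bonds the same, yields a measured number in this pair: in this assay compound 3 gives 9240 nM. Compound 1 gives > 10000 nM, which is a limit of the assay and not a number. The step is an at least 1.0-fold lower number from compound 1 to compound 3 (0.03 log units; that floor lies within the scatter), which is only a floor, and its true size stays unread because of this: the limit of > 10000 nM in this assay, at which 1 of the 3 values shown sits.

Going by these compounds, how far the step can be read as a change between two defined configurations also remains open, because of this: the fact that one of compounds 1 and 3 is drawn with a defined configuration and the other without, at the place where they differ Also open is how the value in this assay would respond if an amide or a primary alcohol took the place of the carboxylic acid on the core of compound 3.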